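A Chloro Step Repeated on a Methoxy Analogue

This account rests on a few compounds, and the source may have more. Where it says the series, first, only, none or still open, it means among the compounds named here.

Compound 1 `c1ccc(CNC(c2ccc[nH]2)c2nnc(-c3ccccc3)o2)cc1` carries the shared core; in a functional assay on A549 cells (Homo sapiens) for cytotoxicity, read by MTT assay, with a stated time of 24 h (a lower number here means a stronger inhibitor, a higher number a weaker inhibitor), compound 1 gives 187000 nM. Compound 2 `Clc1ccc(-c2nnc(C(NCc3ccccc3)c3ccc[nH]3)o2)cc1` differs by chloro in place of hydrogen on an aromatic carbon, and in this assay compound 2 gives 73800 nM, a step of a 2.5-fold lower number from compound 1 to compound 2 (0.40 log units; beyond the scatter). Compound 3 `COc1ccc(CNC(c2ccc[nH]2)c2nnc(-c3ccccc3)o2)cc1` differs from compound 1 by methoxy in place of hydrogen on an aromatic carbon; in this assay compound 3 gives 278000 nM, and the step of a 1.5-fold higher number from compound 1 to compound 3 (0.17 log units; within the scatter) says little. Compound 4 `COc1ccc(CNC(c2ccc[nH]2)c2nnc(-c3cccc(Cl)c3)o2)cc1` is not yet measured; it differs from compound 3 by chloro in place of hydrogen on an aromatic carbon. This is the same kind of change as that from compound 1 to compound 2, yet the chlorine here sits meta to a large group rather than para to a large group, so the earlier step is only a rough guide. Within the data shown here, the expected step is a 2.0-fold lower number from compound 3 to compound 4 (0.30 log units; within the scatter), which rests on the single step of a 2.5-fold lower number from compound 1 to compound 2 (0.40 log units; beyond the scatter). The estimate for compound 4 in this assay is 140000 nM, between 55000 nM and 350000 nM.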

Compound 4, half-maximal inhibitory concentration: 77500 nM
For compound 4 the middle estimate is 1.8-fold (0.26 log units) above the measured one; low and high end bracket the measured number.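

On the methoxy-bearing core, the chloro change again lowers the number in this assay, with a step of a 3.6-fold lower number from compound 3 to compound 4 (0.55 log units; beyond the scatter). Set beside the earlier step, the two agree: the same change on two cores in this assay, a 2.5-fold lower number (0.40 log units; beyond the scatter) from compound 1 to compound 2 and a 3.6-fold lower number (0.55 log units; beyond the scatter) from compound 3 to compound 4, 1.4-fold (0.15 log units) apart, within the scatter of two such steps

Among these compounds, this shows that the change carried over between these two closely related cores, but it rests on only two pairs, and the chlorine of compound 4 sits meta to a large group, unlike that of compound 2, so the effect of its position cannot be separated out. Going by these compounds, it remains open whether a bromine or a methyl group in place of the chlorine would lower the number in the same way. The same question stands for an amine or a carboxylic acid on that ring.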